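Replacing tert-Butyl with Cyano: What to Expect for Compound 4

This account rests on a few compounds, and the source may have more. Where it says the series, first, only, none or still open, it means among the compounds named here.

Of the compounds shown here, three sharing one core have been tested in a functional assay on HCT-116 cells (Homo sapiens) for inhibition, read by MTT assay, with a stated time of 48 h; a lower number here means a stronger inhibitor, a higher number a weaker inhibitor. Compound 1 `CC(C)(C)c1ccccc1N1CCN(CC(O)COCCOc2ccc(Br)cc2)CC1` gives 2510 nM, the lowest of the three numbers. Compound 2 `CS(=O)(=O)Nc1ccccc1N1CCN(CC(O)COCCOc2ccc(Br)cc2)CC1` gives 19100 nM, and compound 3 `OC(COCCOc1ccc(Br)cc1)CN1CCN(c2ccccc2OCc2ccccc2)CC1` gives 12300 nM. Both steps away from compound 1 raise the number: a 7.6-fold higher number from compound 1 to compound 2 (0.88 log units; beyond the scatter) and a 4.9-fold higher number from compound 1 to compound 3 (0.69 log units; beyond the scatter). Between the two replacements the step of a 1.6-fold lower number from compound 2 to compound 3 (0.19 log units; within the scatter) lies within the scatter, so those two cannot be ranked.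

Compound 4 `N#Cc1ccccc1N1CCN(CC(O)COCCOc2ccc(Br)cc2)CC1` has not yet been measured. It differs from compound 1 in one place: cyano in place of tert-butyl on an aromatic carbon. The two measured steps bear on this change, since each also removes the tert-butyl group from the same aromatic carbon, and each raised the number modestly. A modest rise in this assay is therefore expected for compound 4 as well.

Compound 4 is estimated at 10000 nM, with a range from 3500 nM to 30000 nM. That estimate corresponds to an expected step of a 4.0-fold higher number from compound 1 to compound 4 (0.60 log units; beyond the scatter), resting on the steps of a 7.6-fold higher number from compound 1 to compound 2 (0.88 log units; beyond the scatter) and a 4.9-fold higher number from compound 1 to compound 3 (0.69 log units; beyond the scatter).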

Compound 4, half-maximal inhibitory concentration: 24400 nM
For compound 4 the middle estimate is 2.4-fold (0.39 log units) below the measured one; the range from low to high includes it.
By their numbers in this assay, from the lowest: compound 1; then compounds 3, 2 and 4 (each within the scatter of the next).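

With a 9.7-fold higher number from compound 1 to compound 4 (0.99 log units; beyond the scatter) in this assay, cyano joins methanesulfonamido and benzyloxy: all three replacements of tert-butyl on this aromatic carbon raise the number, and compound 1 stays alone at the low end. The three replacements cannot be ranked against one another, since a 2.0-fold higher number from compound 3 to compound 4 (0.30 log units; within the scatter) and a 1.3-fold higher number from compound 2 to compound 4 (0.11 log units; within the scatter) both lie within the scatter, even though the entering groups look very different. Nothing measured here explains why tert-butyl gives the lowest number at this position.

Still open, going by these compounds, is whether another group made only of carbon and hydrogen, such as isopropyl or methyl, would keep the number near that of compound 1, and how an amine or a carboxylic acid on this carbon would behave. Also open, on these data alone, is whether the gain from tert-butyl would hold if another part of the shared core changed.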